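The compounds below may be only part of what the source reports. "The series", "measured", "known", "first", "only" and "open" are said of these compounds alone.

In a functional assay on DU-145 cells (Homo sapiens) for antiproliferative activity, read by MTT assay, with a stated time of 48 h (on this read-out higher numbers stand for weaker inhibition and lower numbers for stronger inhibition), compound 1 `CCN1C(=O)C(O)(Cc2nnn[nH]2)c2ccccc21` gives > 100000 nM, which is a limit of the assay and not a number. Compound 2 `Cc1ccc2c(c1)C(O)(Cc1nnn[nH]1)C(=O)N2C` gives > 100000 nM, which is also a limit, so no number is known for it. Compound 3 `CCN1C(=O)C(O)(Cc2nnn[nH]2)c2cc(C)ccc21` differs from compound 2 by methyl in place of hydrogen on a saturated chain carbon bound to an amide-type nitrogen in a ring, which reads as methyl to ethyl. In this assay the expected change, a step that the limit leaves unreadable from compound 2 to compound 3, is none beyond the usual scatter, because of the limit of > 100000 nM in this assay, at which 2 of the 2 values shown sit. For compound 3 the estimated value is 120000 nM, with an expected range from 60000 nM to 200000 nM.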

Compound 3, half-maximal inhibitory concentration: 14600 nM
The estimate for compound 3 lay 8.2-fold (0.91 log units) above the measured number; the measured number lies below the stated range.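

Compound 3 carries both methyl changes, and only with the two together does a number appear in this assay. Methyl in place of hydrogen on a saturated chain carbon bound to an amide-type nitrogen in a ring gives an at least 6.8-fold lower number from compound 2 to compound 3 (0.83 log units; beyond the scatter), and methyl in place of hydrogen on an aromatic carbon gives an at least 6.8-fold lower number from compound 1 to compound 3 (0.83 log units; beyond the scatter). Neither step has an exact size, because each starts from a limit: the limit of > 100000 nM in this assay, at which 2 of the 3 values shown sit.

As far as these compounds go, whether either change would matter without the other stays open. So does whether a longer chain in place of the ethyl, or a chlorine in place of the aromatic methyl, would lower the number further.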